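The source may report more compounds than this note shows. Statements on the series, on what has been measured and on what is new or still open speak of the compounds shown alone.

Within the data shown here, compound 2 `Cn1cc(-c2cc(-c3cc(Cl)cc(OCCC(F)(F)F)c3)c(=O)n(-c3cccnc3)c2)c(=O)[nH]c1=O` gives 2.26 10^-6 cm/s in an ADME assay for permeability, using PAMPA, in phosphate buffer, with a stated time of 18 h, at pH 7.4 (a higher number here means that the compound crosses the layer faster, a lower number that the compound crosses the layer more slowly), the higher of the two numbers measured so far; compound 1 `O=c1[nH]cc(-c2cc(-c3cc(Cl)cc(OCc4ocnc4C(F)(F)F)c3)c(=O)n(-c3cccnc3)c2)c(=O)[nH]1` gives 0.57 10^-6 cm/s in this assay. Compound 3 `Cn1cc(-c2cc(-c3cc(Cl)cc(OCc4ocnc4C(F)(F)F)c3)c(=O)n(-c3cccnc3)c2)c(=O)[nH]c1=O` has not yet been measured. It differs from compound 2 in one place: a group of 9 heavy atoms (4 carbon, 1 nitrogen, 1 oxygen, 3 fluorine; one five-membered aromatic ring with 2 hetero atoms) in place of a group of 5 heavy atoms (2 carbon, 3 fluorine; no ring), on a saturated chain carbon bound to an oxygen on an aromatic ring. Among the measured compounds shown here, no measured pair shows this change on its own, so the size of the step is uncertain; a modest fall in this assay is expected, possibly no larger than the scatter. For compound 3 the expected value in this assay is 1.2 10^-6 cm/s, with a range from 0.5 10^-6 cm/s to 3 10^-6 cm/s. This amounts to an expected step of a 1.9-fold lower number from compound 2 to compound 3 (0.27 log units; within the scatter).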

Compound 3, apparent permeability: 1.03 10^-6 cm/s
Beside the measured number, compound 3's estimate is 1.2-fold (0.07 log units) above it; measured number inside the range.
By their numbers in this assay, from the lowest: compounds 1 and 3 (each within the scatter of the next); then compound 2.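

Swapping 2,2,2-trifluoroethyl for the larger group with a five-membered aromatic ring, on a saturated chain carbon bound to an oxygen on an aromatic ring, gives a 2.2-fold lower number from compound 2 to compound 3 (0.34 log units; beyond the scatter) in this assay and so shows that this position responds, though modestly. Methyl in place of hydrogen on an aromatic nitrogen gives a 1.8-fold higher number from compound 1 to compound 3 (0.26 log units; within the scatter) and does not clearly separate the two compounds. No measurement at hand explains either step. Going by these compounds, it remains open how an amine or a longer chain would behave at this position. The methyl step is also untested with 2,2,2-trifluoroethyl in place.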